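The source may hold more compounds than are shown below. What is called first, only, known or untested is meant among the compounds shown, and "the series" means these compounds.

Compound 1 `CCO/C(O)=C1\C(C)=NC(C)=C([N+](=O)[O-])C1c1cccnc1` gives 8840 nM in a functional assay (cardiac atrium) for agonist activity, with Cavia porcellus as the target; a higher number here means that more compound is needed for the effect, a lower number that less compound is needed. Compound 2 `CC1=NC(C)=C([N+](=O)[O-])C(c2cccnc2)/C1=C(\O)OC1CCCC1` gives 3280 nM. Compound 3 `CC1=NC(C)=C([N+](=O)[O-])C(c2cccnc2)/C1=C(\O)OC(C)(C)C` gives 14600 nM.

Compound 3 therefore stands at the highest number of the three, with compound 1 nearest and compound 2 furthest away. Compound 4 `CC1=NC(C)=C([N+](=O)[O-])C(c2cccnc2)/C1=C(\O)OC1CCCCC1` differs from compound 3 by cyclohexyl in place of tert-butyl on an oxygen on an unsaturated carbon. For the measured compounds named here, the steps that bear on this change are a 4.5-fold higher number from compound 2 to compound 3 (0.65 log units; beyond the scatter), together with a 2.7-fold lower number from compound 1 to compound 2 (0.43 log units; beyond the scatter) and a 1.7-fold higher number from compound 1 to compound 3 (0.22 log units; within the scatter): the cyclopentyl compound gave the lowest number, while ethyl and tert-butyl lay within the scatter of each other. A cyclohexyl group in this place is therefore expected to bring the number down again, by roughly the size of the cyclopentyl step, namely a 4.2-fold lower number from compound 3 to compound 4 (0.62 log units; beyond the scatter). Compound 4 is thus estimated at 3500 nM, within a range from 1200 nM to 10000 nM.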

Compound 4, half-maximal effective concentration: 2760 nM
The estimate for compound 4 lay 1.3-fold (0.10 log units) above the measured number; the measured number falls inside the stated range.
By their numbers in this assay, from the lowest: compounds 4 and 2 (each within the scatter of the next); then compounds 1 and 3 (each within the scatter of the next).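

Cyclohexyl on this oxygen gives in this assay a 5.3-fold lower number from compound 3 to compound 4 (0.72 log units; beyond the scatter) and a 3.2-fold lower number from compound 1 to compound 4 (0.51 log units; beyond the scatter) in this series, so the low number seen with cyclopentyl no longer rests on one compound. With a 1.2-fold lower number from compound 2 to compound 4 (0.07 log units; within the scatter) the two rings cannot be told apart in this assay. Nothing shown here explains why both ring compounds lie lower than the ethyl and tert-butyl compounds.

The compounds shown leave open whether the ring itself matters, or whether a longer chain such as n-hexyl would give a similar number, and whether a ring carrying an amine would keep it.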